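From Formyl to Carboxy at the Chain End of Compound 2

The compounds below may be only part of what the source reports. "The series", "measured", "known", "first", "only" and "open" are said of these compounds alone.

Compound 1 `Cn1nc(Cc2nnc(SCC(=O)Nc3ccc(Cl)cc3Cl)n2CCC=O)c2ccccc2c1=O`: 6000 nM
Compound 2 `Cn1nc(Cc2nnc(SCCCCCCCC(=O)Nc3ccc(Cl)cc3Cl)n2CCC=O)c2ccccc2c1=O`: 2500 nM

Of the two compounds measured in an assay on 32D cells for inhibition of interleukin-15 (Mus musculus), read by resazurin assay, with stated times of 30 min and 2.5 days, in the presence of a further agent that is not named here (a higher number here means a weaker inhibitor, a lower number a stronger inhibitor), compound 2 gives the lowest number, 2500 nM; its nearest neighbour, compound 1, gives 6000 nM, a gap beyond the scatter. Compound 3 `Cn1nc(Cc2nnc(SCCCCCCCC(=O)Nc3ccc(Cl)cc3Cl)n2CCC(=O)O)c2ccccc2c1=O` differs from compound 2 by hydroxy in place of hydrogen on a carbonyl carbon. For the measured compounds named here, no pair of measured compounds shows what such a change does here, so the expectation rests on compound 2 alone. A step at most modest, and if anything towards a weaker inhibitor, is expected: a 1.4-fold higher number from compound 2 to compound 3 (0.15 log units; within the scatter). Compound 3 is therefore expected to give about 3500 nM, within a range from 1200 nM to 10000 nM.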

Compound 3, half-maximal inhibitory concentration: 23500 nM
For compound 3 the middle estimate is 6.7-fold (0.83 log units) below the measured one; measured number above the stated range.
By their numbers in this assay, from the lowest: compound 2; then compound 1; then compound 3.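

In this assay, replacing 2-formylethyl with 2-carboxyethyl gives a 9.4-fold higher number from compound 2 to compound 3 (0.97 log units; beyond the scatter). This is the first step shown at this position, and it shows that the number here responds strongly to hydroxy in place of hydrogen on a carbonyl carbon, moving towards a weaker inhibitor. No available evidence bears on what lies behind this step.

As far as these compounds go, it remains open whether a methyl ester, a primary amide or an amine at this chain end would stay close to compound 2 or follow compound 3. A longer chain carrying the carboxy group is equally unresolved.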